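Hydroxy to Amino on the Saturated Ring Carbon

The compounds below may be only part of what the source reports. "The series", "measured", "known", "first", "only" and "open" are said of these compounds alone.

Compound 1 `COc1cccc2c1OCC(C)(C)C2N` and compound 2 `CC1(C)COc2ccccc2C1O` have been run in an assay on BTI cells for inhibition of Amine oxidase [flavin-containing] A (Homo sapiens), read by fluorescence, with a stated time of 20 min, tested at 1 uM; on this read-out higher numbers stand for more inhibition at the one concentration tested (going by the name of the read-out) and lower numbers for less inhibition. Compound 1 gives -0.7%. Compound 2 gives 24.3%, the higher of the two numbers, lying beyond the usual scatter from compound 1. Compound 3 `CC1(C)COc2ccccc2C1N` is not yet measured; it differs from compound 2 as follows: amino in place of hydroxy on a saturated ring carbon. For the measured compounds named here, no step between measured compounds that differ in one place is available, so no direct guide exists for this change. The step from compound 2 to compound 3 in this assay is expected to be small, a number 6.3 percentage points lower from compound 2 to compound 3 (within the scatter), not beyond the scatter. For compound 3 in this assay the estimate is 18%, within -5% to 38%.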

Compound 3, a percentage reported as inhibition, at one concentration (the size of the read-out at that concentration, not a potency): -3.8%
The estimate for compound 3 lay 21.8 percentage points above the measured number, and the stated range covers the measured number.
By their numbers in this assay, from the lowest: compounds 3 and 1 (each within the scatter of the next); then compound 2.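

In this assay amino in place of hydroxy on the saturated ring carbon gives a number 28.1 percentage points lower from compound 2 to compound 3 (beyond the scatter) and leaves compound 3 with a lower number than compound 2. With amino on that carbon, hydrogen in place of methoxy on an aromatic carbon gives a number 3.1 percentage points lower from compound 1 to compound 3 (within the scatter), so the methoxy cannot be told apart from hydrogen in this amino pair. Open, as far as these compounds go, is whether methoxy matters with hydroxy on the ring carbon, and whether a methylamino group or a carboxylic acid there reads like hydroxy or like amino. Nothing at hand accounts for the step from hydroxy to amino.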